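This account rests on a few compounds, and the source may have more. Where it says the series, first, only, none or still open, it means among the compounds named here.

Measured in an ADME assay on HEK293 cells (Homo sapiens) for cytotoxicity, read by resazurin assay, with a stated time of 48 h; on this read-out lower numbers stand for higher toxicity in this test and higher numbers for lower toxicity in this test:
compound 1 `O=S(=O)(Nc1ccc(-c2nc3ccccc3o2)cc1)c1cccs1`, reported only as a limit, > 100000 nM.
compound 2 `CCc1ccc(S(=O)(=O)Nc2ccc(-c3nc4ccccc4o3)cc2)cc1`, 82000 nM.

Within the data shown here, compound 2 thus holds the only plain number in this assay. The other value shown is the limit of > 100000 nM in this assay, at which 1 of the 2 values shown sits. Compound 3 `O=S(=O)(Nc1ccc(-c2nc3ccccc3o2)cc1)c1ccc(C(F)(F)F)cc1` differs from compound 2 in one place: trifluoromethyl in place of ethyl on an aromatic carbon. Among the measured compounds shown here, the single measured step, an at least 1.2-fold lower number from compound 1 to compound 2 (0.08 log units; that floor lies within the scatter), concerns a different exchange at the sulfonyl sulfur and does not bear on the present change. For the measured compounds named here, with no step that speaks to it, no change beyond the scatter is expected. Compound 3 is therefore estimated at 85000 nM, ranging from 40000 nM to 180000 nM, an expected step of a 1.0-fold higher number from compound 2 to compound 3 (0.02 log units; within the scatter).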

Compound 3, half-maximal cytotoxic concentration: 94000 nM
Compound 3: middle estimate off by 1.1-fold (0.04 log units), on the low side; the measured number falls inside the stated range.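

In this assay, trifluoromethyl in place of ethyl gives a 1.1-fold higher number from compound 2 to compound 3 (0.06 log units; within the scatter), so this exchange on the aromatic carbon shows no change beyond the scatter. This is the first step shown for a substituent on that six-membered ring, and neither group carries a hydrogen-bond donor or acceptor. Compound 1 is reported only as a limit: the limit of > 100000 nM in this assay, at which 1 of the 3 values shown sits.

The compounds shown leave open whether an amine, a carboxylic acid or a longer chain on this carbon would shift the number beyond the scatter. They also leave open how any such group would compare with ethyl.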